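Methoxymethyl for phenyl, carried to a second core

This account rests on a few compounds, and the source may have more. Where it says the series, first, only, none or still open, it means among the compounds named here.

Compound 1 `CN1CC[C@@H]2CC[C@H](OCc3ccccc3)C[C@@H]21` carries a phenyl on a saturated chain carbon bound to an oxygen on a saturated carbon. In an assay on HEK293 cells for displacement of a labelled ligand from Neuronal acetylcholine receptor; alpha4/beta2 (Rattus norvegicus), with a stated time of 4 h (on this read-out higher numbers stand for weaker inhibition and lower numbers for stronger inhibition), compound 1 gives 100000 nM. Compound 2 `COCCO[C@H]1CC[C@H]2CCN(C)[C@H]2C1` is its methoxymethyl counterpart, and in this assay compound 2 gives 300000 nM. The two differ as methoxymethyl in place of phenyl on a saturated chain carbon bound to an oxygen on a saturated carbon, and the measured step is a 3.0-fold higher number from compound 1 to compound 2 (0.48 log units; beyond the scatter).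

Compound 3 `CN1CCC2=CC[C@H](OCc3ccccc3)C[C@@H]21` keeps the phenyl ether on a different core; how the core of compound 3 differs from the core of compound 1 is not broken down here. In this assay compound 3 gives 300000 nM, which is level with the value of compound 2 within the scatter, while the values of compound 1 and compound 3 stand apart beyond it.

Compound 4 `COCCO[C@H]1CC=C2CCN(C)[C@H]2C1` is not yet measured. It differs from compound 3 as methoxymethyl in place of phenyl on a saturated chain carbon bound to an oxygen on a saturated carbon. Among the measured compounds shown here, the place is the same as in the change from compound 1 to compound 2, so this is the same change made on the second core, and the only measured precedent is a 3.0-fold higher number from compound 1 to compound 2 (0.48 log units; beyond the scatter). For the measured compounds named here, on that basis the expected step is a 3.0-fold higher number from compound 3 to compound 4 (0.48 log units; beyond the scatter), an estimate resting solely on the single precedent. Compound 4 is therefore estimated at 900000 nM in this assay, with an expected range from 300000 nM to 3000000 nM. Since compound 3 already sits at a very weak level, there is a real chance that the run on compound 4 returns only a limit rather than a number.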

Compound 4, inhibition constant: > 300000 nM
Compound 4: a limit, no number (the forecaster's own chance of this, stated with the estimate: 50%); the middle value is on the limit's open side.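

In this assay compound 4 gives > 300000 nM, which is a limit of the assay and not a number. The new step reads a number no lower from compound 3 to compound 4 (the limit leaves the size open) on the second core. Set side by side, the two steps for methoxymethyl in place of phenyl on a saturated chain carbon bound to an oxygen on a saturated carbon read as follows: the same change on two cores in this assay, a 3.0-fold higher number (0.48 log units; beyond the scatter) from compound 1 to compound 2 and a number no lower (the limit leaves the size open) from compound 3 to compound 4; the limit leaves it open whether they differ The result on the second core does not go against the direction seen on the first, but the size of the new step cannot be read, so these notes can claim neither that the change carries over between the two cores with the same size nor that its size depends on the core.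

On these data alone, each core rests on a single pair of compounds, and whether the change behaves alike on both remains open until the second pair gives a number rather than a limit. Also open, as far as these compounds go, is how either core responds to an amine, a carboxylic acid or a longer chain in place of phenyl, and whether any such group moves the values in this assay away from this very weak level.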